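The source may hold more compounds than are shown below. What is called first, only, known or untested is meant among the compounds shown, and "the series" means these compounds.

Measured in a functional assay on MDA-MB-231 cells (Homo sapiens) for antiproliferative activity, read by sulforhodamine B assay, with a stated time of 72 h; on this read-out lower numbers stand for stronger inhibition and higher numbers for weaker inhibition:
compound 1 `CCOC(=O)c1cnc2ccc(-c3cnc(OC)c(NS(C)(=O)=O)c3)cn12`: 190 nM
compound 2 `COc1ncc(-c2ccc3ncc(C(=O)NCc4ccncc4)n3c2)cc1NS(=O)(=O)c1ccc(F)cc1F`: 420 nM
compound 3 `CCOC(=O)c1cn2cc(-c3cnc(OC)c(NS(=O)(=O)c4ccc(F)cc4)c3)ccc2n1`: reported only as a limit, > 20000 nM

Of the two numbers, compound 1 holds the lower one; compound 2 stands higher, and that gap is beyond the scatter. For compound 3 the result is the limit of > 20000 nM in this assay, at which 1 of the 3 values shown sits, a limit and not a number.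

Compound 4 `CCCCS(=O)(=O)Nc1cc(-c2ccc3ncc(C(=O)OCC)n3c2)cnc1OC` is not yet measured. It differs from compound 1 by propyl in place of hydrogen on a saturated chain carbon bound to a sulfonyl sulfur, methanesulfonamido becoming (butylsulfonyl)amino. Among the compounds with values here, no step between measured compounds isolates this change, so nothing anchors its size. In this assay a small step toward weaker inhibition is expected, close to the edge of the scatter, giving a 2.1-fold higher number from compound 1 to compound 4 (0.32 log units; beyond the scatter). For compound 4 the estimate is 400 nM, within 150 nM to 1200 nM.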

Compound 4, half-maximal inhibitory concentration: 2320 nM
Compound 4: middle estimate off by 5.8-fold (0.76 log units), on the low side, outside the stated range (above it).
By their numbers in this assay, from the lowest: compound 1; then compound 2; then compound 4. At a limit, above all of these: compound 3.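

In this assay, the group on the sulfonyl sulfur proves sensitive to chain length: going from methyl to butyl gives a 12-fold higher number from compound 1 to compound 4 (1.09 log units; beyond the scatter). This is the only step shown that changes one place, so it gives the first measured size for a change at this position, and that change weakens inhibition. No measurement shown gives a cause for this step.

One step cannot separate a gradual loss from an abrupt one. Open, on these data alone, are intermediate ethylsulfonyl and propylsulfonyl groups, and a chain ending in an amine or a carboxylic acid.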